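The compounds below may be only part of what the source reports. "The series", "measured", "known", "first", "only" and "open" are said of these compounds alone.

Compound 1, `Nc1cc(N)c2nc(-c3ccccc3)c(Oc3ccc(Cl)c(Cl)c3)nc2c1`, gives 21400 nM in a functional assay on SK-MEL-28 cells (Homo sapiens) for inhibition, read by sulforhodamine B assay, with a stated time of 48 h; on this read-out higher numbers stand for weaker inhibition of growth and lower numbers for stronger inhibition of growth.
Compound 2, `CCOC(=O)[C@H](CCC(=O)O)NC(=O)c1ccc(Oc2nc3cc(N)cc(N)c3nc2-c2ccccc2)cc1`, gives 14500 nM in this assay.
Compound 3, `COc1ccc(CNc2nc3cc(N)cc(N)c3nc2-c2ccccc2)cc1`, gives 17400 nM in this assay.

All three measured compounds share one core and differ only in the group attached to it. On the numbers shown, compound 1 carries the highest of the three, yet its gaps to compound 3 and to compound 2 both fall within the usual scatter of repeated measurements, so the three cannot be told apart, and none of them may be called weaker or stronger than another.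

The compound that has not yet been measured is compound 4, `Nc1cc(N)c2nc(-c3ccccc3)c(Sc3ccc(F)cc3)nc2c1`. It arises from compound 1 by one change: (4-fluorophenyl)sulfanyl in place of 3,4-dichlorophenoxy on an aromatic carbon. In words, a (4-fluorophenyl)sulfanyl group takes the place of the 3,4-dichlorophenoxy group on an aromatic carbon of the core.

Among the measured compounds shown here, no pair among the measured compounds shows this particular swap, so there is no measured step to lean on. What the three measured compounds do show is that different groups at this position leave the numbers within scatter of one another. The expected step from compound 1 to compound 4 is therefore a 1.1-fold lower number from compound 1 to compound 4 (0.03 log units; within the scatter), none beyond the scatter. Compound 4 is estimated at 20000 nM in this assay. Its expected range runs from 7000 nM to 60000 nM.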

Compound 4, concentration for 50% growth inhibition: 23400 nM
Compound 4: the middle estimate sits 1.2-fold (0.07 log units) below what was measured, and the stated range covers the measured number.
By their numbers in this assay, from the lowest: compounds 2, 3, 1 and 4 (each within the scatter of the next).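

In this assay, among the compounds shown here, this is the first pair of compounds differing in one place, so a swap at this aromatic carbon of the shared core can now be read directly: the step is a 1.1-fold higher number from compound 1 to compound 4 (0.04 log units; within the scatter) and therefore gives no sign of a real change in growth inhibition. The swap alters more than one feature at once, since the oxygen link gives way to a sulfur link and the two chlorines on the ring give way to one fluorine, while the six-membered carbon ring itself stays and the counts of hydrogen-bond donors and acceptors match. This single step therefore shows only the net result of the whole swap and cannot assign any share of it to the link or to the ring halogens, and no measurement shown here offers an explanation for the result.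

Still open, as far as these compounds go, is how the sulfur link would read with the 3,4-dichlorophenyl ring kept, or the oxygen link with a 4-fluorophenyl ring. Also open, from the compounds shown here alone, is whether a quite different group at this position, such as a piperidine, a carboxylic acid on the aromatic ring or a longer alkyl chain, would move the number beyond the scatter.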